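Fluoro for methyl on the aryl piperazine of compound 2

The source may report more compounds than this note shows. Statements on the series, on what has been measured and on what is new or still open speak of the compounds shown alone.

Compound 1 `CCC1(CCCCN2CCN(c3ccc(Cl)c(Cl)c3)CC2)C(=O)Nc2ccccc21` and compound 2 `CCC1(CCCCN2CCN(c3ccc(C)c(Cl)c3)CC2)C(=O)Nc2ccccc21` share one core and differ only by methyl in place of chloro on an aromatic carbon. In a functional assay on the whole organism (strain Wistar) with Rattus norvegicus as the target, with a stated time of 5 min (a lower number here means that less compound is needed, a higher number that more compound is needed for the effect), compound 1 reaches only a limit, > 20 mg/kg. In this assay compound 2 likewise reaches only a limit, > 20 mg/kg. The step that the two limits leave unreadable from compound 1 to compound 2 therefore cannot be read. Compound 3 `CCC1(CCCCN2CCN(c3ccc(F)c(Cl)c3)CC2)C(=O)Nc2ccccc21` remains unmeasured; it differs from compound 2 by fluoro in place of methyl on an aromatic carbon. Among the compounds with values here, the single measured step, methyl in place of chloro on an aromatic carbon, left both compounds unresolved, and the limit of > 20 mg/kg in this assay, at which 2 of the 2 values shown sit, gives no numbered point from which a direction could be taken. For compound 3 in this assay the expected step is a step that the limit leaves unreadable from compound 2 to compound 3, with no direction beyond the scatter supported. The estimate for compound 3 in this assay is 25 mg/kg, ranging from 8 mg/kg to 80 mg/kg, with a fair chance that only a limit is again reported.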

Compound 3, minimum effective dose: > 20 mg/kg
Compound 3: no number, only a limit; the forecaster's own chance of this, stated with the estimate: 70%; the middle value does not contradict the limit.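

Compound 3 also reaches only a limit in this assay, > 20 mg/kg. Within the data shown here, no step among compound 1, compound 2 and compound 3 can be read: the limit of > 20 mg/kg in this assay, at which 3 of the 3 values shown sit. The compounds shown leave open whether any group on this aromatic carbon gives a numbered minimum effective dose in this assay.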